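A few compounds are considered here, and "the series" means these few. Any claim that something is new, unique, unknown or untested is made for them only; others in the source may bear on it.

Compounds 1, 2 and 3 share one core and differ only in the group carried on an amine nitrogen in a ring. Compound 1 `CC(C)N1CCN(Cc2csc(N)c2C(=O)c2ccc(Cl)cc2)CC1` bears an isopropyl there, and in an assay on CHO cells for displacement of a labelled ligand from adenosine receptor A3 (Homo sapiens), read by scintillation counting, with a stated time of 120 min, tested at 10 uM (on this read-out higher numbers stand for more inhibition at the one concentration tested (going by the name of the read-out) and lower numbers for less inhibition), compound 1 gives 0%. Compound 2 `Nc1scc(CN2CCN(c3cccc(C(F)(F)F)c3)CC2)c1C(=O)c1ccc(Cl)cc1` bears a 3-(trifluoromethyl)phenyl, and in this assay compound 2 gives 0%. Compound 3 `Nc1scc(CN2CCN(c3ccc(F)cc3F)CC2)c1C(=O)c1ccc(Cl)cc1` bears a 2,4-difluorophenyl, and in this assay compound 3 gives 0%, level with compounds 1 and 2. The three steps between them are no change at the digits printed from compound 1 to compound 2 (within the scatter), no change at the digits printed from compound 1 to compound 3 (within the scatter) and no change at the digits printed from compound 2 to compound 3 (within the scatter), each within the scatter.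

Compound 4 `Nc1scc(CN2CCN(CCCc3ccc(Cl)cc3)CC2)c1C(=O)c1ccc(Cl)cc1` is not yet measured. Its difference from compound 3 is 3-(4-chlorophenyl)propyl in place of 2,4-difluorophenyl on an amine nitrogen in a ring. All three measured steps bear on this change, since each also swaps the group on that same ring nitrogen, and none of them moved the read-out beyond the scatter. The expected step is therefore a number 2 percentage points higher from compound 3 to compound 4 (within the scatter), that is, no change beyond the scatter. For compound 4 the estimate in this assay is 2%, expected to fall between -8% and 15%.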

Compound 4, a percentage reported as inhibition, at one concentration (the size of the read-out at that concentration, not a potency): 0%
Compound 4: the middle estimate sits 2 percentage points above what was measured; measured number inside the range.
By their numbers in this assay, from the lowest: compounds 1, 2, 3 and 4 (each within the scatter of the next).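

With 3-(4-chlorophenyl)propyl, the aromatic ring hangs on a propyl chain instead of sitting directly on the ring nitrogen, yet the outcome in this assay is the same as before: (no change at the digits printed from compound 3 to compound 4 (within the scatter)), (no change at the digits printed from compound 2 to compound 4 (within the scatter)) and (no change at the digits printed from compound 1 to compound 4 (within the scatter)). A chain-carried aromatic ring therefore joins isopropyl and the two directly attached aromatic rings as a group on this nitrogen that leaves the read-out unmoved, so these four compounds give no ranking of the groups. Nothing measured here offers an explanation for this flat result.

From the compounds shown here alone, it remains open whether a different group on that nitrogen, such as a chain ending in a carboxylic acid or in a primary amine, would give measurable inhibition. Going by these compounds, it is equally open whether any group at this position can do so on the shared core.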